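This account rests on a few compounds, and the source may have more. Where it says the series, first, only, none or still open, it means among the compounds named here.

Compound 1 `c1ccc(C(/N=C2\CCCCCN2)c2ccco2)cc1`: 34%
Compound 2 `c1ccc(C(/N=C2\CCCCCCN2)c2ccco2)cc1`: 29%
Compound 3 `c1ccc(C(/N=C2\CCCCCN2)c2cccs2)cc1`: 36%

All three were tested in a functional assay on the whole organism (plasma, strain Sprague-Dawley) with Rattus norvegicus as the target, with a stated time of 2 h, at a dose of 25 mg/kg by the oral route; a lower number here means a weaker effect, a higher number a stronger effect of the compound at the dose given. Compound 1 and compound 3 differ in one place only: thiophen-2-yl in place of furan-2-yl on a saturated chain carbon bound to an aromatic carbon and a double-bonded nitrogen. The measured step, a number 2 percentage points higher from compound 1 to compound 3 (within the scatter), stays within the scatter, so the two numbers cannot be told apart. Compound 2 has a different core from compound 1; the difference between the two cores is not broken down here. Compound 4, `c1ccc(C(/N=C2\CCCCCCN2)c2cccs2)cc1`, has not been measured yet. It stands to compound 2 exactly as compound 3 stands to compound 1: thiophen-2-yl in place of furan-2-yl on a saturated chain carbon bound to an aromatic carbon and a double-bonded nitrogen. This is the same change at the same place. Because the earlier step of a number 2 percentage points higher from compound 1 to compound 3 (within the scatter) lay within the scatter, the step from compound 2 to compound 4 is expected to be small as well, a number 2 percentage points higher from compound 2 to compound 4 (within the scatter). Compound 4 is therefore estimated at 31%, likely between 18% and 44%.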

Compound 4, a percentage reported as inhibition, in the whole organism at one dose (the size of the read-out at that dose, not a potency): 37%
For compound 4 the middle estimate is 6 percentage points below the measured one, within the range that was stated.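

Swapping furan-2-yl for thiophen-2-yl has now been read on two cores, and in this assay the new step is a number 8 percentage points higher from compound 2 to compound 4 (within the scatter). Set beside the earlier step, the two agree: the same change on two cores in this assay, a number 2 percentage points higher (within the scatter) from compound 1 to compound 3 and a number 8 percentage points higher (within the scatter) from compound 2 to compound 4, 6 percentage points apart, within the scatter of two such steps. So the swap carries across these two cores without a visible difference, but neither step stands clear of the scatter, and this does not show that the swap has a real effect on either core or that it would behave alike on a third.

The compounds shown carry only furan-2-yl or thiophen-2-yl at this place, so what an amine or a carboxylic acid would do there stays open. Each compound also appears at a single dose and time, which leaves other doses open.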